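Alkyl variation on the saturated ring carbon of the dichloro series

This account rests on a few compounds, and the source may have more. Where it says the series, first, only, none or still open, it means among the compounds named here.

Measured compounds:
- compound 1 `CC1(C2CCCC2)Cc2cc(OCc3cccc(-c4nn[nH]n4)c3)c(Cl)c(Cl)c2C1=O`: 371 nM
- compound 2 `O=C1c2c(cc(OCc3ccc(-c4nn[nH]n4)cc3)c(Cl)c2Cl)CC1C1CCCC1`: 122 nM
- compound 3 `CC(C)C1Cc2cc(OCc3ccc(-c4nn[nH]n4)cc3)c(Cl)c(Cl)c2C1=O`: 195 nM

In an assay on isolated protein for binding affinity to metabotropic glutamate receptor 2 (Homo sapiens) (on this read-out lower numbers stand for an effect already at smaller amounts and higher numbers for an effect only at larger amounts of compound), compound 3 stands second highest of the three numbers. Its nearest neighbour is compound 2, and the step of a 1.6-fold higher number from compound 2 to compound 3 (0.20 log units; within the scatter) lies within the scatter; compound 1 differs from compound 2 in more than one place, so only the two values themselves can be set side by side, and they too lie within the scatter of each other.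

The next compound, compound 4 `CCCC1Cc2cc(OCc3ccc(-c4nn[nH]n4)cc3)c(Cl)c(Cl)c2C1=O`, carries the change (propyl in place of isopropyl on a saturated ring carbon). Going by the values given here, only one measured step bears on this position, the step of a 1.6-fold higher number from compound 2 to compound 3 (0.20 log units; within the scatter), which exchanged one saturated hydrocarbon group for another on the same carbon and stayed within the scatter. Exchanging isopropyl for propyl is a smaller change of the same kind, so no step beyond the scatter in this assay is expected.

Compound 4 is therefore expected near 200 nM, in the range 100 nM to 400 nM, a step of a 1.0-fold higher number from compound 3 to compound 4 (0.01 log units; within the scatter) that is expected to stay within the scatter.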

Compound 4, half-maximal effective concentration: 282 nM
Compound 4: middle estimate off by 1.4-fold (0.15 log units), on the low side; the range from low to high includes it.
By their numbers in this assay, from the lowest: compounds 2, 3, 4 and 1 (each within the scatter of the next, the first and the last beyond it).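

In this assay, moving from isopropyl to propyl, the same three carbons joined differently on the saturated ring carbon, gives a step that stays within the scatter (a 1.4-fold higher number from compound 3 to compound 4 (0.16 log units; within the scatter)). Going by these compounds alone, the exchange of cyclopentyl for propyl is the first change at this position to pass the scatter, though only modestly (a 2.3-fold higher number from compound 2 to compound 4 (0.36 log units; beyond the scatter)), whereas the exchange of cyclopentyl for isopropyl does not pass it (a 1.6-fold higher number from compound 2 to compound 3 (0.20 log units; within the scatter)). No measurement at hand accounts for either step.

Still open, going by these compounds, is how this carbon responds to a longer chain such as hexyl, or to a chain ending in an amine or a carboxylic acid. The effect of the methyl on this carbon in compound 1 also remains unresolved, since that compound differs from the others in more than one place.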